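Fluorophenyl position in the thiourea series

The source may report more compounds than this note shows. Statements on the series, on what has been measured and on what is new or still open speak of the compounds shown alone.

compound 1 `Fc1ccc(NC(=S)Nc2cccc(C(F)(F)F)c2)cc1`: 26000 nM
compound 2 `Fc1ccccc1NC(=S)Nc1cccc(C(F)(F)F)c1`: 54000 nM

In an ADME assay on BHK cells (Mesocricetus auratus) for cytotoxicity, read by MTT assay, with a stated time of 96 h (on this read-out lower numbers stand for higher toxicity in this test and higher numbers for lower toxicity in this test), compound 2 stands highest of the two at 54000 nM. Compound 3 `Fc1cccc(NC(=S)Nc2cccc(C(F)(F)F)c2)c1` carries 3-fluorophenyl in place of 2-fluorophenyl on an amide-type nitrogen. For the measured compounds named here, one measured step bears on this, the modest 2.1-fold higher number from compound 1 to compound 2 (0.32 log units; beyond the scatter), with 2-fluorophenyl in place of 4-fluorophenyl. Going by the values given here, no measured compound yet carries 3-fluorophenyl. A smaller step towards compound 1 is therefore expected, possibly none beyond the scatter. The expected change is a 1.4-fold lower number from compound 2 to compound 3 (0.15 log units; within the scatter). For compound 3 the estimated value is 38000 nM, with an expected range of 18000 nM to 75000 nM.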

Compound 3, half-maximal cytotoxic concentration: 9400 nM
Beside the measured number, compound 3's estimate is 4.0-fold (0.61 log units) above it; measured number below the stated range.
By their numbers in this assay, from the lowest: compound 3; then compound 1; then compound 2.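

In this assay the 3-fluorophenyl isomer does not fall between the other two, with a 5.7-fold lower number from compound 2 to compound 3 (0.76 log units; beyond the scatter) and a 2.8-fold lower number from compound 1 to compound 3 (0.44 log units; beyond the scatter) placing compound 3 lowest of the three. Moving the fluorine alone therefore shifts this number further than the earlier step alone showed. Nothing at hand accounts for this order.

Open, going by these compounds, is whether the low number belongs to fluorine itself or would also appear with chlorine in its place. Also open, on these data alone, is whether it survives replacing the trifluoromethyl group with a nitrile.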